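Adding an ethoxy group beside the phenol: an untested step

The source may hold more compounds than are shown below. What is called first, only, known or untested is meant among the compounds shown, and "the series" means these compounds.

Of the compounds shown here, two have been measured. Compound 1 `O=C(N/N=C/c1ccccn1)c1cccc(S(=O)(=O)N2CCOCC2)c1` gives 44300 nM in a functional assay on EC9706 cells (Homo sapiens) for antiproliferative activity, read by MTT assay, with a stated time of 72 h; on this read-out higher numbers stand for weaker inhibition and lower numbers for stronger inhibition. Compound 2 `O=C(N/N=C/c1ccccc1O)c1cccc(S(=O)(=O)N2CCOCC2)c1` gives 19600 nM in the same assay, and the change from compound 1 to compound 2, a 2-hydroxyphenyl in place of pyridin-2-yl, brought a 2.3-fold lower number from compound 1 to compound 2 (0.35 log units; beyond the scatter). Compound 2 therefore stands with the lower of the two numbers recorded so far, meaning the stronger inhibition.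

Compound 3 `CCOc1cccc(/C=N/NC(=O)c2cccc(S(=O)(=O)N3CCOCC3)c2)c1O` has not been measured. It differs from compound 2 in one place: ethoxy in place of hydrogen on an aromatic carbon. For the measured compounds named here, no measured step involves this kind of change; the only step recorded concerns a different part of the molecule, so nothing recorded speaks directly for or against a shift. The expectation for compound 3 is a number close to that of compound 2, as an estimate of 15000 nM with a range of 6000 nM to 40000 nM, which corresponds to an expected step of a 1.3-fold lower number from compound 2 to compound 3 (0.12 log units; within the scatter).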

Compound 3, half-maximal inhibitory concentration: 15400 nM
Estimate against measurement, compound 3: 1.0-fold (0.01 log units) below; the measured number falls inside the stated range.
By their numbers in this assay, from the lowest: compounds 3 and 2 (each within the scatter of the next); then compound 1.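

The ethoxy group, placed ortho to the hydroxy group, brings a 1.3-fold lower number from compound 2 to compound 3 (0.10 log units; within the scatter) in this assay and so shows that this position of the ring can carry the added group with no readable change in the number. Replacing pyridin-2-yl with 3-ethoxy-2-hydroxyphenyl gives a 2.9-fold lower number from compound 1 to compound 3 (0.46 log units; beyond the scatter) as a modest step, and a similar step, a 2.3-fold lower number from compound 1 to compound 2 (0.35 log units; beyond the scatter), is already present without the ethoxy group. No measurement on hand offers an explanation for this result.

The compounds shown leave open whether a longer chain such as butoxy, or an amine, at this position would move the number beyond the scatter. They also leave open whether the ethoxy group would read the same way if the neighbouring hydroxy group were replaced by a methoxy group.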